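This account rests on a few compounds, and the source may have more. Where it says the series, first, only, none or still open, it means among the compounds named here.

Working notes on the series.

Compound 1 `CCOC(=O)c1cnc(NN2C(=O)C=C(C)C2=O)nc1-c1cc2ccccc2s1` gives 800 nM in a functional assay on Jurkat cells (Homo sapiens) for inhibition; on this read-out lower numbers stand for stronger inhibition and higher numbers for weaker inhibition. Compound 2 `CCOC(=O)c1cnc(NN2C(=O)C=C(C)C2=O)nc1-c1nccs1` gives 2200 nM in this assay. Compound 3 `CCOC(=O)c1cnc(N(C)N2C(=O)C=C(C)C2=O)nc1-c1cc2ccccc2s1` gives 130 nM in this assay. Compound 4 `CCOC(=O)c1cnc(N(C)N2C(=O)C=C(C)C2=O)nc1-c1nccs1` is not yet measured.

Compound 3 differs from compound 1 by methyl in place of hydrogen on a nitrogen on an aromatic ring, a change that gave a 6.2-fold lower number from compound 1 to compound 3 (0.79 log units; beyond the scatter). Among the three measured compounds compound 3 has the lowest number, with both steps to it beyond the scatter.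

The change from compound 1 to compound 2 is 1,3-thiazol-2-yl in place of 1-benzothiophen-2-yl on an aromatic carbon; it gave a 2.8-fold higher number from compound 1 to compound 2 (0.44 log units; beyond the scatter). The change from compound 3 to compound 4 is 1,3-thiazol-2-yl in place of 1-benzothiophen-2-yl on an aromatic carbon. It is the same kind of change, on a core that carries the methyl of compound 3 rather than the hydrogen of compound 1; around the place the only difference in wording is "meta to a large group" for compound 4 against "meta to a group of 9 heavy atoms" for compound 2.

Compound 4 is expected to sit at 360 nM, a step of a 2.8-fold higher number from compound 3 to compound 4 (0.44 log units; beyond the scatter) from compound 3, resting on the size of a 2.8-fold higher number from compound 1 to compound 2 (0.44 log units; beyond the scatter) seen for the same change; the estimate is expected to fall between 150 nM and 900 nM.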

Compound 4, half-maximal inhibitory concentration: 1700 nM
The estimate for compound 4 lay 4.7-fold (0.67 log units) below the measured number; measured number above the stated range.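

In this assay the exchange of 1-benzothiophen-2-yl for 1,3-thiazol-2-yl gives a 13-fold higher number from compound 3 to compound 4 (1.12 log units; beyond the scatter), and the size of this step does not carry over between the two cores: the same change on two cores in this assay, a 2.8-fold higher number (0.44 log units; beyond the scatter) from compound 1 to compound 2 and a 13-fold higher number (1.12 log units; beyond the scatter) from compound 3 to compound 4, 4.8-fold (0.68 log units) apart, beyond the scatter of two such steps. Methyl in place of hydrogen on the nitrogen gives a 1.3-fold lower number from compound 2 to compound 4 (0.11 log units; within the scatter), so the step seen with 1-benzothiophen-2-yl does not recur with 1,3-thiazol-2-yl: the same change on two cores in this assay, a 6.2-fold lower number (0.79 log units; beyond the scatter) from compound 1 to compound 3 and a 1.3-fold lower number (0.11 log units; within the scatter) from compound 2 to compound 4, 4.8-fold (0.68 log units) apart, beyond the scatter of two such steps. The exchange raises the number on both cores, but its size on one core is a poor guide to its size on the other, and these four compounds form a single pair of cores that cannot show why the steps differ or whether other groups would behave the same way.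

Still open, on these data alone, is whether the methyl step depends on the group at this place, which a phenyl or a thiophen-2-yl there would test. Also open, as far as these compounds go, is whether an ethyl on the nitrogen, or a carboxylic acid in place of the ethoxycarbonyl group, would behave alike on both cores.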